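The source may report more compounds than this note shows. Statements on the series, on what has been measured and on what is new or still open speak of the compounds shown alone.

The measured compounds:
compound 1 `COc1ccccc1-c1nc(Cc2c[nH]c3ccccc23)no1` — 42200 nM
compound 2 `COc1ccc(-c2nc(Cc3c[nH]c4ccccc34)no2)c(OC)c1` — 9300 nM
compound 3 `COc1ccc(OC)c(-c2nc(Cc3c[nH]c4ccccc34)no2)c1` — > 50000 nM

In an ADME assay on cells (Splenocyte, Mus musculus, strain BALB/c) for cytotoxicity, read by CCK-8 assay, with a stated time of 48 h (a lower number here means that less compound is tolerated, a higher number that more compound is tolerated), compound 1 gives 42200 nM, the highest of the two plain numbers. Its nearest neighbour is compound 2, reached by a 4.5-fold lower number from compound 1 to compound 2 (0.66 log units; beyond the scatter). For compound 3 the assay reports only a limit, > 50000 nM, which is the limit of > 50000 nM in this assay, at which 1 of the 3 values shown sits. That step, an at least 1.1-fold higher number from compound 1 to compound 3 (0.07 log units; that floor lies within the scatter), is therefore open-ended at the top.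

Compound 4 `Fc1ccccc1-c1nc(Cc2c[nH]c3ccccc23)no1` differs from compound 1 in one place: fluoro in place of methoxy on an aromatic carbon. Neither measured step shows this kind of exchange. Both add a methoxy in place of hydrogen on an aromatic carbon and point in different directions: one modest fall, one change whose floor sits within the scatter. They offer no direct guide to trading the methoxy of compound 1 for a fluoro, so the expectation is a step near zero in this assay, with no firm direction.

Compound 4 is accordingly expected to give about 38000 nM, with a plausible span from 15000 nM to 50000 nM. The expected step is a 1.1-fold lower number from compound 1 to compound 4 (0.05 log units; within the scatter), likely within the scatter, and since compound 1 already sits close to the limit of the assay, a limit rather than a number is a real possibility for compound 4.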

Compound 4, half-maximal cytotoxic concentration: > 50000 nM
Compound 4: a limit, no number (the forecaster's own chance of this, stated with the estimate: 35%); at least 1.3-fold (0.11 log units) between middle value and limit.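

In this assay, the exchange of methoxy for fluoro on the aromatic carbon ortho to a large group gives an at least 1.1-fold higher number from compound 1 to compound 4 (0.07 log units; that floor lies within the scatter), the first change shown that removes the methoxy of compound 1 instead of adding a second one. The high number of compound 1 therefore does not depend on keeping a methoxy at this place, since the smaller fluoro, with no hydrogen-bond acceptor counted for it, leaves no measurable fall in this series. Compound 4 gives a limit and not a number, so the size of the step cannot be read past its floor, and the upper end of the range now holds a second compound: the limit of > 50000 nM in this assay, at which 2 of the 4 values shown sit.

Going by these compounds, how far compound 4 lies past that limit stays open, as does whether an amine, a carboxylic acid or a longer chain such as ethoxy at this place would bring the number down into the measurable range. Also open, on these data alone, is whether the added methoxy behind a 4.5-fold lower number from compound 1 to compound 2 (0.66 log units; beyond the scatter) would have a similar effect on compound 4, which carries fluoro in place of the methoxy of compound 1.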